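The source may report more compounds than this note shows. Statements on the series, on what has been measured and on what is new or still open speak of the compounds shown alone.

Measured compounds:
compound 1 `c1ccc(CCSCc2cnc3ccc(-c4ccccc4)cn23)cc1` — 9.9 ug/mL
compound 2 `Cc1cc(-c2ccsc2)c2ncc(CSCCc3ccccc3)n2c1` — > 50 ug/mL, a limit
compound 3 `Cc1cc(-c2ccc(O)cc2)cn2c(CSCCc3ccccc3)cnc12` — > 50 ug/mL, a limit

In an ADME assay on HEL cells (Homo sapiens) for cytotoxicity, with a stated time of 3 days (on this read-out lower numbers stand for higher toxicity in this test and higher numbers for lower toxicity in this test), compound 1 gives 9.9 ug/mL. Compound 2 gives only a limit, > 50 ug/mL. Compound 3 likewise gives only a limit, > 50 ug/mL. Among the measured compounds shown here, compound 3 therefore stands at the limit of > 50 ug/mL in this assay, at which 2 of the 3 values shown sit, and no step between it and any other measured compound can be sized; the gap to compound 1 is only that compound 1 gives a number while compound 3 does not.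

Compound 4 `Cc1cc(-c2cccs2)cn2c(CSCCc3ccccc3)cnc12` differs from compound 3 by thiophen-2-yl in place of 4-hydroxyphenyl on an aromatic carbon. For the measured compounds named here, no step between measured compounds covers this change. The nearest comparison is compound 2, which also bears a thiophene ring on the same core and in this assay gives > 50 ug/mL, a limit. Compound 4 is expected to give 60 ug/mL, between 25 ug/mL and 150 ug/mL, most likely again reported only as a limit. The step this estimate implies, a step that the limit leaves unreadable from compound 3 to compound 4, is expected to be none beyond the scatter.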

Compound 4, half-maximal cytotoxic concentration: 32 ug/mL
For compound 4 the middle estimate is 1.9-fold (0.27 log units) above the measured one; the measured number falls inside the stated range.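

In this assay, thiophen-2-yl in place of 4-hydroxyphenyl on this aromatic carbon, meta to a methyl group, gives an at least 1.5-fold lower number from compound 3 to compound 4 (0.19 log units; that floor lies within the scatter). The change therefore brings a readable number to this position on the methyl-bearing core, but the step is only a floor and does not show a real shift in toxicity. Its full size cannot be read because compound 3 sits at a limit: the limit of > 50 ug/mL in this assay, at which 2 of the 4 values shown sit.

The swap replaces a six-membered aromatic ring with a five-membered one and removes the hydroxyl in the same step, and the compounds shown do not separate these two parts. From the compounds shown here alone, how a 4-aminophenyl group or a phenyl ring bearing a carboxylic acid would read at this carbon remains open.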